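Two measured diaryl ureas and an untested third

The compounds below may be only part of what the source reports. "The series", "measured", "known", "first", "only" and "open" are said of these compounds alone.

Compound 1: `CCNc1cc(-c2ccc(NC(=O)Nc3ccc(C(F)(F)F)cc3)cc2C)ccn1`, 19700 nM
Compound 2: `CCNc1cc(-c2ccc(NC(=O)Nc3cccc(Cl)c3)cc2C(F)(F)F)ccn1`, 13300 nM

Going by the values given here, the two compounds measured so far share a core and differ in two places at once, so no single step between them is isolated. In a functional assay on BT-483 cells (Homo sapiens) for cytotoxicity, read by MTT assay, with a stated time of 24 h (a higher number here means a weaker inhibitor, a lower number a stronger inhibitor), compound 1 gives 19700 nM. In this assay compound 2 gives 13300 nM, the lower of the two numbers, though the gap to compound 1 lies within the usual scatter and no order between them can be claimed.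

Compound 3 is `CCNc1cc(-c2ccc(NC(=O)Nc3ccc(C(F)(F)F)cc3)cc2C(F)(F)F)ccn1`. It differs from compound 2 in one place: 4-(trifluoromethyl)phenyl in place of 3-chlorophenyl on an amide-type nitrogen. Compound 3 thus carries the urea substituent of compound 1 on the core of compound 2. Since the two measured compounds sit within the scatter of each other while differing in both places, the data give no sign that this change moves the number in either direction. Compound 3 is therefore expected to show no step beyond the scatter, with a 1.1-fold higher number from compound 2 to compound 3 (0.05 log units; within the scatter) as the anticipated change. For compound 3 the estimate is 15000 nM, within a range of 6000 nM to 40000 nM.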

Compound 3, half-maximal inhibitory concentration: 16400 nM
Estimate against measurement, compound 3: 1.1-fold (0.04 log units) below; measured number inside the range.
By their numbers in this assay, from the lowest: compounds 2, 3 and 1 (each within the scatter of the next).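

In this assay, the exchange of 3-chlorophenyl for 4-(trifluoromethyl)phenyl on an amide-type nitrogen can now be read on its own, and it amounts to a 1.2-fold higher number from compound 2 to compound 3 (0.09 log units; within the scatter) on the core of compound 2, so this position does not separate these two aryl groups. Trifluoromethyl in place of methyl on an aromatic carbon can also be read alone, with 4-(trifluoromethyl)phenyl held fixed on the urea, and a 1.2-fold lower number from compound 1 to compound 3 (0.08 log units; within the scatter) shows that this exchange does not separate the two groups either. Compounds 1 and 2 could show these two changes only together, and nothing at hand explains why neither one, taken singly, moves the number beyond the scatter.

The compounds shown leave open whether any group on the amide-type nitrogen other than these two substituted phenyl rings, such as one bearing a carboxylic acid or an amine, would give a step beyond the scatter. As far as these compounds go, it also remains open whether a longer chain in place of the ethyl group, or a chlorine in place of the trifluoromethyl on the aromatic carbon, would change the number in this assay.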